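The source may report more compounds than this note shows. Statements on the series, on what has been measured and on what is new or still open speak of the compounds shown alone.

Measured so far:
- Compound 1, `Oc1ccc(-c2cc(-c3ccoc3)cc(-c3cccc(O)c3)n2)cc1`: in a functional assay on HeLa cells (Homo sapiens) for cytotoxicity, read by CCK-8 assay (on this read-out lower numbers stand for stronger inhibition and higher numbers for weaker inhibition), compound 1 gives 3310 nM
- Compound 2, `Oc1cccc(-c2cc(-c3ccccn3)cc(-c3ccccc3O)n2)c1`: in this assay compound 2 gives 2020 nM

For the measured compounds named here, compound 2 stands at one of only two numbers so far, and its gap to compound 1 lies within the scatter, so the two cannot be told apart on this read-out. Compound 3, `Oc1ccc(-c2cc(-c3ccccn3)cc(-c3cccc(O)c3)n2)cc1`, is not yet measured. Against compound 2 the change is 4-hydroxyphenyl in place of 2-hydroxyphenyl on an aromatic carbon. Going by the values given here, with no step between measured compounds to lean on, and compound 1 carrying the same 4-hydroxyphenyl group at a value close to that of compound 2, no step beyond the scatter is expected in either direction. Compound 3 is therefore estimated at 2500 nM, range 1000 nM to 6500 nM, which means an expected step of a 1.2-fold higher number from compound 2 to compound 3 (0.09 log units; within the scatter).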

Compound 3, half-maximal inhibitory concentration: 1930 nM
For compound 3 the middle estimate is 1.3-fold (0.11 log units) above the measured one, within the range that was stated.
By their numbers in this assay, from the lowest: compounds 3, 2 and 1 (each within the scatter of the next).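

In this assay, 4-hydroxyphenyl in place of 2-hydroxyphenyl on the aromatic carbon next to the ring nitrogen gives a 1.0-fold lower number from compound 2 to compound 3 (0.02 log units; within the scatter) and so leaves these two groups indistinguishable at this position. Pyridin-2-yl in place of furan-3-yl gives a 1.7-fold lower number from compound 1 to compound 3 (0.23 log units; within the scatter) and is likewise no change that can be read on this read-out.

As far as these compounds go, whether an amine or a carboxylic acid in place of the hydroxyl on this ring would give a step beyond the scatter stays open. No data at hand speak to the cause of these results.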